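Removing the hydroxyl from an aryl-amino side chain

This account rests on a few compounds, and the source may have more. Where it says the series, first, only, none or still open, it means among the compounds named here.

Measured in an assay on isolated protein for inhibition of serine/threonine-protein kinase TNNI3K (Homo sapiens); a higher number here means a weaker inhibitor, a lower number a stronger inhibitor:
Compound 1 `O=C(Nc1ccc(Oc2ccncn2)cc1)Nc1cccc(C(F)(F)F)c1` gives 160 nM
Compound 2 `C[C@H](O)CNc1cc(Oc2ccc(NC(=O)Nc3cccc(C(F)(F)F)c3)cc2)ncn1` gives 32 nM

Among the compounds with values here, compound 2 has the lower of the two numbers; the only step measured, a 5.0-fold lower number from compound 1 to compound 2 (0.70 log units; beyond the scatter), is modest but beyond the scatter. Compound 3 `CC(C)Nc1cc(Oc2ccc(NC(=O)Nc3cccc(C(F)(F)F)c3)cc2)ncn1` carries isopropyl in place of 2-hydroxypropyl on a nitrogen on an aromatic ring. Within the data shown here, no measured step touches the hydroxyl itself, so this change is judged only by the gain from compound 1 to compound 2, part of which may come from the amino chain as such. Compound 3 is therefore expected to lose little, giving a 1.7-fold higher number from compound 2 to compound 3 (0.24 log units; within the scatter), with an estimate of 55 nM in this assay and a range from 20 nM to 160 nM.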

Compound 3, half-maximal inhibitory concentration: 40 nM
Compound 3: middle estimate off by 1.4-fold (0.14 log units), on the high side; measured number inside the range.
By their numbers in this assay, from the lowest: compounds 2 and 3 (each within the scatter of the next); then compound 1.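

In this assay the hydroxyl of the 2-hydroxypropyl chain can be exchanged for isopropyl with a 1.3-fold higher number from compound 2 to compound 3 (0.10 log units; within the scatter) and the two compounds stay within the scatter, so neither the hydroxyl nor the defined stereocentre is needed to hold this level. Isopropylamino alone also keeps a gain over hydrogen on the aromatic carbon, with a 4.0-fold lower number from compound 1 to compound 3 (0.60 log units; beyond the scatter) as the step beyond the scatter. No evidence is available to explain either step. The compounds shown leave open whether a longer chain, or a chain ending in an amine or a carboxylic acid, would hold this level on the same nitrogen. They also leave open whether a single methyl there would keep the gain over compound 1.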